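Three cytotoxicity limits and an untested methyl homologue

The source may hold more compounds than are shown below. What is called first, only, known or untested is meant among the compounds shown, and "the series" means these compounds.

The study sets three small heterocycles side by side. Compound 1 `Cc1ccc(C2ON=C(c3ccccc3Cl)O2)cc1` and compound 2 `CCc1ccc(C2ON=C(c3ccccc3Cl)O2)cc1` share one core, and compound 3 `CC1(c2cccc(Br)c2)ON=C(c2ccccc2Cl)O1` is built on a related but different one; the difference between the two cores is not broken down here. In an ADME assay on HEK293 cells (Homo sapiens) for cytotoxicity, read by MTT assay, with a stated time of 44 h (on this read-out higher numbers stand for weaker inhibition and lower numbers for stronger inhibition), compound 1 gives > 100000 nM, which is a limit of the assay and not a number. In this assay compound 2 likewise gives > 100000 nM, again a limit. In this assay compound 3 gives > 100000 nM, also a limit. The change from compound 1 to compound 2 is methyl in place of hydrogen on a saturated chain carbon bound to an aromatic carbon, and the step it made, a step that the two limits leave unreadable from compound 1 to compound 2, cannot be sized, because the limit of > 100000 nM in this assay, at which 3 of the 3 values shown sit, holds every value shown.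

Compound 4 `CCC1(c2cccc(Br)c2)ON=C(c2ccccc2Cl)O1` has not been measured in this assay. It arises from compound 3 by methyl in place of hydrogen on a saturated chain carbon bound to a saturated ring carbon, the same kind of change as that from compound 1 to compound 2, though the place differs: there the carbon is bound to an aromatic carbon, here to a saturated ring carbon. The expected step from compound 3 to compound 4 in this assay is a step that the limit leaves unreadable from compound 3 to compound 4, resting on the fact that compound 3 sits at the limit of > 100000 nM in this assay, at which 3 of the 3 values shown sit, and that a step that the two limits leave unreadable from compound 1 to compound 2 gave no readable shift. Compound 4 is therefore estimated at 150000 nM, between 60000 nM and 500000 nM, most likely reported only as a limit. The actual measurement follows.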

Compound 4, half-maximal inhibitory concentration: > 100000 nM
Compound 4: only a limit was reported; the forecaster's own chance of this, stated with the estimate: 85%; the middle value is on the limit's open side.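

Going by these compounds alone, compound 4, like compound 3, is reported only as a limit, so no step from compound 3 to compound 4 can be read in this assay, because the two limits give no size to compare: the limit of > 100000 nM in this assay, at which 4 of the 4 values shown sit.

The compounds shown leave open how strongly any of them acts in this assay, and whether any change to them would give a value that is not a limit.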